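The source may hold more compounds than are shown below. What is called first, only, known or untested is meant among the compounds shown, and "the series" means these compounds.

In an ADME assay on L1210/0 cells (Mus musculus) for cytotoxicity, with a stated time of 48 h (on this read-out higher numbers stand for weaker inhibition and lower numbers for stronger inhibition), compound 3 `O=c1[nH]c(=O)n([C@H]2C[C@H](O)[C@@H](CO)O2)cc1C#Cc1ccccc1` gives only a limit, > 200000 nM, and no number. Compound 2 `C[S+]([O-])c1cn([C@H]2C[C@H](O)[C@@H](CO)O2)c(=O)[nH]c1=O` also gives only a limit, > 200000 nM. This is the limit of > 200000 nM in this assay, at which 2 of the 3 values shown sit. Compound 1 `O=c1[nH]c(=O)n([C@H]2C[C@H](O)[C@@H](CO)O2)cc1/C=N/O` gives a number, 15500 nM.

The next change leads to compound 4 `O=c1[nH]c(=O)n([C@H]2C[C@H](O)[C@@H](CO)O2)cc1C1SCCS1`: a group of 5 heavy atoms (3 carbon, 2 sulfur; one five-membered non-aromatic ring with 2 hetero atoms) in place of a group of 8 heavy atoms (8 carbon; one six-membered aromatic ring of carbon only), on an aromatic carbon. The 2-phenylethynyl leaves, and a group with no common name enters, with one five-membered non-aromatic ring with 2 hetero atoms.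

Going by the values given here, two measured steps bear on this: an at least 12-fold higher number from compound 1 to compound 3 (1.11 log units; beyond the scatter) and an at least 12-fold higher number from compound 1 to compound 2 (1.11 log units; beyond the scatter). Each is large and beyond the scatter, while a step that the two limits leave unreadable from compound 2 to compound 3 gives no readable size. Among the compounds with values here, no measured step starts from a number at compound 3, and compound 4 lacks the group of compound 1 as well. In this assay a small move to a lower number is therefore expected, or none beyond the scatter, and a further limit is quite possible. The estimated step is an at least 1.3-fold lower number from compound 3 to compound 4 (0.12 log units; that floor lies within the scatter). For compound 4 the expected value is 150000 nM. The estimated range for compound 4 runs from 30000 nM to 300000 nM.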

Compound 4, half-maximal inhibitory concentration: > 200000 nM
Compound 4: no number, only a limit; the forecaster's own chance of this, stated with the estimate: 55%; at least 1.3-fold (0.12 log units) between middle value and limit.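

In this assay compound 4 gives only a limit, so a group with one five-membered non-aromatic ring with 2 hetero atoms, counted with 2 hydrogen-bond acceptors, yields no number on this aromatic carbon, just as the 2-phenylethynyl group with none does not. Going by these compounds alone, the one readable new step is an at least 12-fold higher number from compound 1 to compound 4 (1.11 log units; beyond the scatter), while the steps linking compound 2, compound 3 and compound 4 to one another cannot be read. Of the four groups shown at this position, only the one in compound 1 gives a number, and the rest share one limit: the limit of > 200000 nM in this assay, at which 3 of the 4 values shown sit.

As far as these compounds go, the order among compound 2, compound 3 and compound 4 stays unknown. From the compounds shown here alone, whether an amine or a carboxylic acid on this aromatic carbon would also give a number, as compound 1 does with 15500 nM, remains open.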